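This account rests on a few compounds, and the source may have more. Where it says the series, first, only, none or still open, it means among the compounds named here.

Of the compounds shown here, three have been measured in a functional assay on HCT-116 cells (Homo sapiens) for cytotoxicity, read by MTT assay, with a stated time of 72 h; a higher number here means a weaker inhibitor, a lower number a stronger inhibitor. Compound 1 `Cc1cc(-c2ccccc2)n(/C(N)=N/S(=O)(=O)c2cc(C)c(Cl)cc2SCc2ccccc2C)n1` gives 42000 nM, compound 2 `Cc1cc(-c2ccccc2)n(/C(N)=N/S(=O)(=O)c2cc(C)c(Cl)cc2SCc2ccc(C(F)(F)F)cc2)n1` gives 7000 nM, and compound 3 `Cc1ccc(CSc2cc(Cl)c(C)cc2S(=O)(=O)/N=C(\N)n2nccc2-c2ccccc2)cc1` gives 14000 nM. Among the compounds with values here, the only step between compounds that differ in one place is a 6.0-fold lower number from compound 1 to compound 2 (0.78 log units; beyond the scatter), and it concerns the group on the saturated chain carbon bound to a sulfur. Compound 3 stands second highest of the three numbers: nearest to compound 2, within the scatter, and furthest from compound 1, beyond the scatter.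

Compound 4 `Cc1ccc(CSc2cc(Cl)c(C)cc2S(=O)(=O)/N=C(\N)n2nc(C)cc2-c2ccccc2)cc1` differs from compound 3 in one place: methyl in place of hydrogen on an aromatic carbon. Within the data shown here, no measured step bears on this change; compounds 1 and 2 carry the methyl on that aromatic carbon but also differ from compound 3 in the group on the saturated chain carbon bound to a sulfur, so their numbers cannot be separated into two contributions. With nothing pointing either way, the expected step is no change at the digits printed from compound 3 to compound 4 (within the scatter), none beyond the scatter. The estimate for compound 4 in this assay is 14000 nM, with a range from 5000 nM to 40000 nM.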

Compound 4, half-maximal inhibitory concentration: 28000 nM
Compound 4: middle estimate off by 2.0-fold (0.30 log units), on the low side; measured number inside the range.
By their numbers in this assay, from the lowest: compounds 2, 3, 4 and 1 (each within the scatter of the next, the first and the last beyond it).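

In this assay, methyl in place of hydrogen on the aromatic carbon of the five-membered aromatic ring now has a direct reading, a 2.0-fold higher number from compound 3 to compound 4 (0.30 log units; within the scatter), so this change shows no effect beyond the scatter in this pair. With that methyl present in compounds 1, 2 and 4, the group on the saturated chain carbon bound to a sulfur can be read alone: 4-methylphenyl in place of 2-methylphenyl gives a 1.5-fold lower number from compound 1 to compound 4 (0.18 log units; within the scatter), while methyl in place of trifluoromethyl gives a 4.0-fold higher number from compound 2 to compound 4 (0.60 log units; beyond the scatter). Among these three compounds, only the trifluoromethyl group separates one compound from the other two beyond the scatter.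

Nothing available explains any of these steps. On these data alone, whether an ethyl group or an amine on the same aromatic carbon of the five-membered ring would stay within the scatter remains open, as does whether chlorine in place of trifluoromethyl would keep the number of compound 2.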